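The compounds below may be only part of what the source reports. "The series", "measured", "known", "first", "only" and "open" are said of these compounds alone.

Compound 1, `CNc1nc(C)c(C(=O)N/N=C/c2cccc(C(F)(F)F)c2)s1`, was tested in a functional assay on MCF7 cells (Homo sapiens) for inhibition, read by MTT assay, with a stated time of 72 h; a lower number here means a stronger inhibitor, a higher number a weaker inhibitor. In this assay compound 1 gives > 100 ug/mL, which is a limit of the assay rather than a number. Compound 2, `CNc1nc(C(F)(F)F)c(C(=O)N/N=C/c2cccc(C(F)(F)F)c2)s1`, likewise gives only a limit in this assay, namely > 100 ug/mL. The change between them, (trifluoromethyl in place of methyl on an aromatic carbon), yields a step that the two limits leave unreadable from compound 1 to compound 2 because both values sit at the limit of > 100 ug/mL in this assay, at which 2 of the 3 values shown sit.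

Compound 3, `Cc1nc(N(C)C(=O)NC(=O)c2c(F)cccc2F)sc1C(=O)N/N=C/c1cc(C(F)(F)F)cc(C(F)(F)F)c1`, is built on a different core; the difference between the two cores is not broken down here. In this assay, going by the values given here, compound 3 gives 11.6 ug/mL, the only true number among the three values shown so far.

Compound 4, `CN(C(=O)NC(=O)c1c(F)cccc1F)c1nc(C(F)(F)F)c(C(=O)N/N=C/c2cc(C(F)(F)F)cc(C(F)(F)F)c2)s1`, differs from compound 3 by trifluoromethyl in place of methyl on an aromatic carbon. This is the same kind of change as that from compound 1 to compound 2, though the surroundings differ: there the place was two ring bonds from the ring atom that bears a methylamino group (2 heavy atoms), here it is two ring bonds from the ring atom that bears a large group. Since the earlier step that the two limits leave unreadable from compound 1 to compound 2 has no readable size, the new step is expected to be a 1.0-fold higher number from compound 3 to compound 4 (0.01 log units; within the scatter), a change of roughly the size of repeat scatter. Compound 4 is therefore estimated to give 12 ug/mL in this assay, most likely between 5 ug/mL and 30 ug/mL.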

Compound 4, half-maximal inhibitory concentration: 6.85 ug/mL
The estimate for compound 4 lay 1.8-fold (0.24 log units) above the measured number; the measured number falls inside the stated range.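

In this assay, trifluoromethyl in place of methyl on the core of compound 3 gives a 1.7-fold lower number from compound 3 to compound 4 (0.23 log units; within the scatter), a step that stays inside the ordinary scatter of repeat measurements. Going by these compounds alone, the same swap on the core of compound 1 cannot be read, because compound 1 and compound 2 both carry a limit of the assay and not a number: the limit of > 100 ug/mL in this assay, at which 2 of the 4 values shown sit. This leaves only one readable step, so it shows that on the core of compound 3 the swap leaves both compounds with a measurable value, but it does not show whether the step carries over from one core to the other.

The compounds shown leave open what other groups on this aromatic carbon would give, such as a carboxylic acid, a nitrile or a longer chain like ethyl. Also open, going by these compounds, is which of the several differences between the two cores separates the limits from the true numbers.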